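A few compounds are considered here, and "the series" means these few. Any claim that something is new, unique, unknown or untested is made for them only; others in the source may bear on it.

Two compounds share one core and differ only in the amine fixed to a thiocarbonyl carbon. Compound 1 `CC(C)N(C(=S)SCc1oc2ccccc2c(=O)c1Cl)C(C)C` carries a diisopropylamino group there, while compound 2 `O=c1c(Cl)c(CSC(=S)N2CCCC2)oc2ccccc12` carries pyrrolidin-1-yl. In a functional assay on SW480 cells (Homo sapiens) for antiproliferative activity, read by MTT assay, with a stated time of 72 h (on this read-out higher numbers stand for weaker inhibition and lower numbers for stronger inhibition), compound 1 gives 18100 nM, and compound 2 gives 1400 nM. Going by the values given here, the single measured step, a 13-fold lower number from compound 1 to compound 2 (1.11 log units; beyond the scatter), shows that exchanging the amine on this carbon can shift the read-out a long way. Compound 2 therefore stands with the lowest number of the two, well apart from compound 1.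

Compound 3 `O=c1c(Cl)c(CSC(=S)N2CCOCC2)oc2ccccc12` changes the same position again: morpholin-4-yl in place of pyrrolidin-1-yl on a thiocarbonyl carbon. Both groups are non-aromatic cyclic amines, and the entering ring brings one oxygen counted as a hydrogen-bond acceptor. Among the compounds with values here, the only step that bears on this change, a 13-fold lower number from compound 1 to compound 2 (1.11 log units; beyond the scatter), concerned a quite different amine exchange, so it sets no firm direction; a modest step in this assay is expected, more likely toward weaker inhibition. Compound 3 is expected to give about 2500 nM in this assay, within a range from 700 nM to 9000 nM. The expected step is estimated as a 1.8-fold higher number from compound 2 to compound 3 (0.25 log units; within the scatter), not reliably beyond the scatter.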

Compound 3, half-maximal inhibitory concentration: 1800 nM
Estimate against measurement, compound 3: 1.4-fold (0.14 log units) above; low and high end bracket the measured number.
By their numbers in this assay, from the lowest: compounds 2 and 3 (each within the scatter of the next); then compound 1.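

In this assay, the exchange of pyrrolidin-1-yl for morpholin-4-yl on the thiocarbonyl carbon gives a 1.3-fold higher number from compound 2 to compound 3 (0.11 log units; within the scatter), so going from a five-membered to a six-membered ring and adding a ring oxygen, counted as one hydrogen-bond acceptor, leaves no change that can be told from the scatter. Measured against the diisopropylamino group of compound 1, morpholin-4-yl gives a 10-fold lower number from compound 1 to compound 3 (1.00 log units; beyond the scatter), so among these three compounds both ring amines stand well apart from the one amine without a ring, and the large step seen earlier is not confined to pyrrolidin-1-yl. No measurement available here gives a reason for either step.

Three amines cannot show whether the ring itself matters or some other difference from diisopropylamino, and dimethylamino or diethylamino, as smaller amines without a ring, would help separate these two readings. Piperidin-1-yl would show how a six-membered ring behaves without the oxygen, while piperazin-1-yl would show the effect of a second ring nitrogen in its place.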